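The source may report more compounds than this note shows. Statements on the series, on what has been measured and on what is new or still open speak of the compounds shown alone.

Series notes. The three measured compounds share the core seen in compound 3, `O=C(/C=C/c1ccsc1)c1cc(O)c(O)c([N+](=O)[O-])c1`, and were tested in an assay on isolated protein for inhibition of Amine oxidase [flavin-containing] B (Homo sapiens), read by fluorescence; a higher number here means a weaker inhibitor, a lower number a stronger inhibitor. Compound 1, `CC(=O)N1N=C(c2cc(O)c(O)c([N+](=O)[O-])c2)CC1c1cccc(C#N)c1`, gives 55400 nM; compound 2, `N#Cc1ccc(/C=C/C(=O)c2cc(O)c(O)c([N+](=O)[O-])c2)cc1`, gives 56600 nM; compound 3 gives 42100 nM. On these three numbers compound 3 stands lowest, but its gap to compound 1 and its gap to compound 2 both lie within the usual scatter of repeated measurements, so no order among the three can be read from them.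

The next compound, compound 4, `O=C(/C=C/c1nccs1)c1cc(O)c(O)c([N+](=O)[O-])c1`, has not yet been measured in this assay. It differs from compound 3 in one place: 1,3-thiazol-2-yl in place of thiophen-3-yl on a double-bonded chain carbon bound to a double-bonded chain carbon. Going by the values given here, no pair of measured compounds in this set differs in a single place, so there is no measured step to lean on. What the set does show is that compound 1 at 55400 nM, compound 2 at 56600 nM and compound 3 at 42100 nM all sit within the scatter of one another although each carries a different group at the same place, which points to a small step here as well. For compound 4 the expectation is a step of a 1.1-fold higher number from compound 3 to compound 4 (0.03 log units; within the scatter), that is, none beyond the scatter. Compound 4 is therefore estimated at 45000 nM in this assay, with a range from 20000 nM to 100000 nM.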

Compound 4, half-maximal inhibitory concentration: 59200 nM
Compound 4: middle estimate off by 1.3-fold (0.12 log units), on the low side; the measured number falls inside the stated range.
By their numbers in this assay, from the lowest: compounds 3, 1, 2 and 4 (each within the scatter of the next).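

In this assay, the series now has its first measured single-place step: 1,3-thiazol-2-yl in place of thiophen-3-yl on a double-bonded chain carbon bound to a double-bonded chain carbon gives a 1.4-fold higher number from compound 3 to compound 4 (0.15 log units; within the scatter). This turns the earlier indirect impression of a flat position into one direct comparison: going from one five-membered aromatic ring with 1 hetero atom to one with 2 hetero atoms, and from 1 hydrogen-bond acceptor to 2, with the heavy-atom count unchanged, yields no difference that can be told from the scatter. No measurement of any property bears on this result, so the step can be recorded but not explained.

From the compounds shown here alone, one step between two five-membered aromatic rings says little about the position as a whole, and it remains open whether an amine, a carboxylic acid or a longer chain at this place would move the number beyond the scatter. Going by these compounds, it also remains open whether any single change elsewhere on the shared core, for example to its nitro group or its hydroxyl groups, would do so.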